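Swapping the Thiophene Arm of a Caspase-8 Inhibitor

The source may report more compounds than this note shows. Statements on the series, on what has been measured and on what is new or still open speak of the compounds shown alone.

Compound 1, `CCCCCCN(C)CNCC(=O)[C@H](CC(=O)O)NC(=O)C(CC)n1cc(C(C)(CC)CC)nc(NCc2nonc2C)c1=O`: in an assay for inhibition of Caspase-8 (Homo sapiens) (on this read-out higher numbers stand for weaker inhibition and lower numbers for stronger inhibition), compound 1 reports only a limit, > 10000 nM.
Compound 2, `CCC(C(=O)N[C@@H](CC(=O)O)C(=O)CSCc1ccccc1)n1ccnc(NCc2cccs2)c1=O`: in this assay compound 2 gives 2090 nM.
Compound 3, `CCC(C(=O)N[C@@H](CC(=O)O)C(=O)CNCN1CCC(Cc2ccccc2)CC1)n1ccnc(NCc2nonc2C)c1=O`: in this assay compound 3 gives 6020 nM.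

Compound 1 sits at the edge of what the method can report, (the limit of > 10000 nM in this assay, at which 1 of the 3 values shown sits), and so contributes no number. Of the two numbers that are known, compound 2 holds the lower one, and compound 3 lies beyond the usual scatter from it. Compound 4, `CCC(C(=O)N[C@@H](CC(=O)O)C(=O)CSCc1ccccc1)n1ccnc(NCC2COc3ccccc3O2)c1=O`, has not yet been tested in this assay. It differs from compound 2 in a single place: 2,3-dihydro-1,4-benzodioxin-2-yl in place of thiophen-2-yl on a saturated chain carbon bound to a nitrogen on an aromatic ring. No measured pair among these compounds shows the effect of such an exchange, so its size is open. The step is expected to be a 1.2-fold higher number from compound 2 to compound 4 (0.08 log units; within the scatter), within the usual scatter and without a clear direction. Compound 4 is therefore estimated at 2500 nM in this assay, within a range from 800 nM to 8000 nM.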

Compound 4, half-maximal inhibitory concentration: 8220 nM
The estimate for compound 4 lay 3.3-fold (0.52 log units) below the measured number, and the stated range ends below it.
By their numbers in this assay, from the lowest: compound 2; then compounds 3 and 4 (each within the scatter of the next). At a limit, above all of these: compound 1.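

The exchange of thiophen-2-yl for 2,3-dihydro-1,4-benzodioxin-2-yl on a saturated chain carbon bound to a nitrogen on an aromatic ring gives the first step measured at this place in this assay: a 3.9-fold higher number from compound 2 to compound 4 (0.59 log units; beyond the scatter). It shows that this position is not indifferent to the group it carries, and that in this one pair the entering bicyclic group goes with weaker inhibition. Nothing measured here accounts for the size or direction of this step.

Among these compounds, with only two groups compared at this place, it remains open whether thiophen-2-yl is especially favourable or 2,3-dihydro-1,4-benzodioxin-2-yl especially unfavourable. How a phenyl or a pyridin-2-yl group would read at the same place is also open, as is whether the step would carry over to the other cores shown.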